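Compound 4: Hydrogen in Place of 4-Methylphenyl

The source may hold more compounds than are shown below. What is called first, only, known or untested is meant among the compounds shown, and "the series" means these compounds.

Measured in an ADME assay on Vero cells (Chlorocebus sabaeus) for cytotoxicity, with a stated time of 4 days; a higher number here means a weaker inhibitor, a lower number a stronger inhibitor:
- Compound 1 `Cc1ccc(OCc2cn(-c3ccc(S(=O)(=O)N4CCc5ccccc5C4)cc3)nn2)cc1`: > 50 ug/mL
- Compound 2 `COc1cc2c(cc1OC)CN(S(=O)(=O)c1ccc(-n3cc(COc4ccc(C=O)cc4)nn3)cc1)CC2`: > 50 ug/mL
- Compound 3 `COc1cc2c(cc1OC)CN(S(=O)(=O)c1ccc(-n3cc(COc4ccccc4C)nn3)cc1)CC2`: > 50 ug/mL

Each of these three entries is a limit and not a number. Compound 1 therefore has no exact position, and > 50 ug/mL is only its limit.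

Compound 4 `O=S(=O)(c1ccc(-n2cc(CO)nn2)cc1)N1CCc2ccccc2C1` is not yet measured. It differs from compound 1 as follows: hydrogen in place of 4-methylphenyl on an oxygen on a saturated carbon. In words, this is hydrogen in place of 4-methylphenyl on an oxygen on a saturated carbon, so 4-methylphenoxy becomes hydroxy.

Within the data shown here, only one measured step touches that oxygen, namely a step that the two limits leave unreadable from compound 2 to compound 3. There, 2-methylphenyl stands in place of 4-formylphenyl, and the step gives no size to carry over. Among the measured compounds shown here, none of the measured compounds has hydrogen on that oxygen, so this estimate reaches beyond them.

Because of the limit of > 50 ug/mL in this assay, at which 3 of the 3 values shown sit, no step beyond the scatter is expected in this assay, and no direction can be given. The expected step is a step that the limit leaves unreadable from compound 1 to compound 4. For compound 4 the estimated value is 60 ug/mL, with an expected range of 30 ug/mL to 120 ug/mL.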

Compound 4, half-maximal inhibitory concentration: > 50 ug/mL
Compound 4 was reported as a limit; the forecaster's own chance of this, stated with the estimate: 80%; the middle value lies beyond the limit too.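

In this assay compound 4 gives > 50 ug/mL, which is a limit and not a number. No step from compound 1 to compound 4 can be read, because both sit at the same limit: the limit of > 50 ug/mL in this assay, at which 4 of the 4 values shown sit.

The compounds shown leave open where any actual value lies, and so whether hydrogen in place of 4-methylphenyl changes the result at all.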